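Swapping Trifluoromethyl for Chloro on the Aryl Urea

A few compounds are considered here, and "the series" means these few. Any claim that something is new, unique, unknown or untested is made for them only; others in the source may bear on it.

Measured in a functional assay on NCI-H460 cells (Homo sapiens) for inhibition, read by MTT assay, with a stated time of 72 h; a higher number here means a weaker inhibitor, a lower number a stronger inhibitor:
- compound 1 `COc1cc(NC(C)CCCNC(=O)Nc2cccc(C(F)(F)F)c2)c2ncccc2c1` gives 21000 nM
- compound 2 `COc1cc(NC(C)CCCNC(=O)NNC(=O)Nc2cccc(C(F)(F)F)c2)c2ncccc2c1` gives 20000 nM

Compound 2 stands level with compound 1, and the two numbers lie within the scatter of each other. These two values are all that is known so far, and neither compound offers a measured exchange of a group on the aromatic ring.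

The next compound is compound 3 `COc1cc(NC(C)CCCNC(=O)NNC(=O)Nc2cccc(Cl)c2)c2ncccc2c1`, which differs from compound 2 at one place. It carries chloro in place of trifluoromethyl on an aromatic carbon, and the rest of the structure stays the same.

Among the measured compounds shown here, with no measured precedent for this exchange, no shift beyond the scatter is expected in this assay. The expected change is small, as the step of a 1.1-fold higher number from compound 2 to compound 3 (0.04 log units; within the scatter). For compound 3 the estimated value is 22000 nM, with an expected range from 10000 nM to 45000 nM.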

Compound 3, half-maximal inhibitory concentration: 32000 nM
For compound 3 the middle estimate is 1.5-fold (0.16 log units) below the measured one, and the stated range covers the measured number.
By their numbers in this assay, from the lowest: compounds 2, 1 and 3 (each within the scatter of the next).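

In this assay, among the compounds shown here, chloro in place of trifluoromethyl on the aromatic carbon gives a 1.6-fold higher number from compound 2 to compound 3 (0.20 log units; within the scatter), the first measured exchange at this position, and it stays within the scatter. The other step available, a 1.5-fold higher number from compound 1 to compound 3 (0.18 log units; within the scatter), also stays within the scatter, so all three compounds remain level in this assay, and neither change to the aryl urea end separates them. Nothing measured here bears on why these numbers stand as they do.

The compounds shown leave open whether an amine, a carboxylic acid or a methoxy group on this aromatic carbon would move the number beyond the scatter. They also leave open whether chloro would behave the same way on the urea of compound 1, which carries trifluoromethyl at this place.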